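Replacing the Hydroxy on Compound 3 with Ethoxycarbonyl

This account rests on a few compounds, and the source may have more. Where it says the series, first, only, none or still open, it means among the compounds named here.

Going by the values given here, compound 3 `CCN(Cc1ccc(O)cc1)C(=O)c1nc(-c2ccccc2)c2ccccc2n1` stands highest of the three numbers measured so far: in an assay on cell membranes from kidney for displacement of a labelled ligand from Translocator protein (Rattus norvegicus) (a higher number here means a weaker inhibitor, a lower number a stronger inhibitor), compound 3 gives 8.76 nM. Compound 1 `CCN(Cc1ccc(C)cc1)C(=O)c1nc(-c2ccccc2)c2ccccc2n1` gives 2.57 nM and compound 2 `CCN(Cc1ccc(OC)cc1)C(=O)c1nc(-c2ccccc2)c2ccccc2n1` gives 2.77 nM. Compound 4 `CCOC(=O)c1ccc(CN(CC)C(=O)c2nc(-c3ccccc3)c3ccccc3n2)cc1` differs from compound 3 by ethoxycarbonyl in place of hydroxy on an aromatic carbon. Among the compounds with values here, the steps that bear on this are the two that remove the same hydroxy: a 3.4-fold higher number from compound 1 to compound 3 (0.53 log units; beyond the scatter) and a 3.2-fold higher number from compound 2 to compound 3 (0.50 log units; beyond the scatter), both modest and beyond the scatter, while a 1.1-fold higher number from compound 1 to compound 2 (0.03 log units; within the scatter). Exchanging the hydroxy for a group with no hydrogen-bond donor is therefore expected to give a lower number, of the size a 2.5-fold lower number from compound 3 to compound 4 (0.40 log units; beyond the scatter). For compound 4 the expected value in this assay is 3.5 nM, with a range from 1.2 nM to 10 nM.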

Compound 4, inhibition constant: 3.65 nM
Estimate against measurement, compound 4: 1.0-fold (0.02 log units) below; low and high end bracket the measured number.
By their numbers in this assay, from the lowest: compounds 1, 2 and 4 (each within the scatter of the next); then compound 3.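

At this place, para to a large group, ethoxycarbonyl brings far more heavy atoms than hydroxy yet gives a lower number (a 2.4-fold lower number from compound 3 to compound 4 (0.38 log units; beyond the scatter)). It also stays level with the smaller groups (a 1.3-fold higher number from compound 2 to compound 4 (0.12 log units; within the scatter); a 1.4-fold higher number from compound 1 to compound 4 (0.15 log units; within the scatter)), so this position accepts a much larger group without a measurable loss, and among the four compounds only hydroxy stands apart. No measurement shown here explains that difference. From the compounds shown here alone, whether a carboxylic acid, an amine or a longer ester chain would stay level at this place remains open, as does whether ethoxycarbonyl would behave alike elsewhere on this ring.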